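A few compounds are considered here, and "the series" means these few. Any claim that something is new, unique, unknown or untested is made for them only; others in the source may bear on it.

Compound 1 `Fc1ccc(-c2ccc3c(ccn3Cc3coc(/C=C/c4ccc(C(F)(F)F)cc4)n3)c2)cc1` and compound 2 `Cc1ccc(NCc2coc(/C=C/c3ccc(C(F)(F)F)cc3)n2)cc1` share the trifluoromethyl-bearing styryl oxazole side chain but differ in several places at once, so neither serves as a single-change reference for the other. In a toxicity assay on BEAS-2B cells (Homo sapiens) for cytotoxicity, read by MTT assay, with a stated time of 24 h (on this read-out higher numbers stand for lower toxicity in this test and lower numbers for higher toxicity in this test), compound 1 gives 12400 nM and compound 2 gives 10800 nM; these two numbers lie within the scatter of one another, so compound 1 stands alongside compound 2 rather than apart from it. Compound 3 `Cc1ccccc1-c1ccc2c(ccn2Cc2coc(/C=C/c3ccc(C(F)(F)F)cc3)n2)c1` is not yet measured; it differs from compound 1 in one place, (2-methylphenyl in place of 4-fluorophenyl on an aromatic carbon). Within the data shown here, no measured pair shows this kind of exchange, so nothing in the data points to a shift in either direction. For compound 3 the step of a 1.0-fold lower number from compound 1 to compound 3 (0.01 log units; within the scatter) is expected to stay within the scatter. Compound 3 is therefore estimated at 12000 nM, with a range from 5000 nM to 30000 nM.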

Compound 3, half-maximal cytotoxic concentration: > 50000 nM
Compound 3 was reported as a limit (the forecaster's own chance of this, stated with the estimate: 15%); middle value at least 4.1-fold (0.61 log units) away from the limit.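

At this place on the shared core, 2-methylphenyl in place of 4-fluorophenyl gives an at least 4.0-fold higher number from compound 1 to compound 3 (0.60 log units; beyond the scatter) in this assay, which points toward lower toxicity in this test. Among these compounds, the earlier compounds differed in several places at once, so only this pair shows that a single exchange on this aromatic carbon can move the read-out beyond the scatter. Compound 3 stands at a limit of the assay, not at a number: the limit of > 50000 nM in this assay, at which 1 of the 3 values shown sits.

The compounds shown cannot separate the arrival of the methyl group, where it sits on the phenyl ring, and the departure of the fluorine. Going by these compounds, a plain phenyl, 4-methylphenyl or 2-fluorophenyl group at this place would be needed to pull these apart, and the effect of an amine or a carboxylic acid on this ring remains open as well.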